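Aryl exchange on the shared core: compound 2 to compound 3

A few compounds are considered here, and "the series" means these few. Any claim that something is new, unique, unknown or untested is made for them only; others in the source may bear on it.

Measured in a functional assay on KBVIN cells (Homo sapiens) for antiproliferative activity, read by sulforhodamine B assay, with a stated time of 3 days; a lower number here means that less compound is needed, a higher number that more compound is needed for the effect:
- Compound 1 `CCC1=C(O)c2c(oc(-c3ccc(F)cc3)cc2=O)C(CC)(CC)C1=O`: 1.85 uM
- Compound 2 `CCC1=C(O)c2c(oc(-c3ccccc3OC)cc2=O)C(CC)(CC)C1=O`: 3.26 uM

Within the data shown here, compound 2 stands within the scatter of compound 1, the only other measured compound. Compound 3 `CCC1=C(O)c2c(oc(-c3ccc(C)cc3C)cc2=O)C(CC)(CC)C1=O` has 2,4-dimethylphenyl in place of 2-methoxyphenyl on an aromatic carbon. Among the measured compounds shown here, the one measured step, a 1.8-fold higher number from compound 1 to compound 2 (0.25 log units; within the scatter), exchanges the group at the same place. For the measured compounds named here, it is the only guide, so no step beyond the scatter is expected in this assay. The expected step is a 1.3-fold lower number from compound 2 to compound 3 (0.12 log units; within the scatter). Compound 3 is estimated at 2.5 uM, with an expected range of 1.2 uM to 5.5 uM.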

Compound 3, concentration for half-maximal effect: 8.52 uM
The estimate for compound 3 lay 3.4-fold (0.53 log units) below the measured number; measured number outside the range, above it.
By their numbers in this assay, from the lowest: compounds 1 and 2 (each within the scatter of the next); then compound 3.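

At this aryl position on the shared core, this assay now separates the groups: a 2.6-fold higher number from compound 2 to compound 3 (0.42 log units; beyond the scatter) and a 4.6-fold higher number from compound 1 to compound 3 (0.66 log units; beyond the scatter) both lie beyond the scatter, which the earlier exchange did not. With 8 heavy atoms in each group, 2-methoxyphenyl has 1 hydrogen-bond acceptor and 2,4-dimethylphenyl has 0, so the higher number comes with a change that leaves the heavy-atom count equal. No measurement at hand accounts for this result.

Going by these compounds, whether 2-methylphenyl or 4-methylphenyl alone gives a similar number remains open. So does how an aminophenyl or carboxyphenyl group would read at this position.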